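Oxime ether chain: ethyl to cyclopentyl on the oxygen

The source may hold more compounds than are shown below. What is called first, only, known or untested is meant among the compounds shown, and "the series" means these compounds.

Among the compounds with values here, compound 2 `CCO/N=C/c1c(N)ncnc1Oc1ccc(NC(=O)C2(C(=O)Nc3ccc(F)cc3)CC2)cc1F` gives 3.41 in a physicochemical assay for lipophilicity, using the shake flask method (on this read-out lower numbers stand for lower lipophilicity and higher numbers for higher lipophilicity), the second highest of the three numbers so far. Compound 1 `C=CCO/N=C/c1c(N)ncnc1Oc1ccc(NC(=O)C2(C(=O)Nc3ccc(F)cc3)CC2)cc1F` gives 3.65 in this assay, and the difference between the two is a number 0.24 log units lower from compound 1 to compound 2 (within the scatter). Compound 3 `Nc1ncnc(Oc2ccc(NC(=O)C3(C(=O)Nc4ccc(F)cc4)CC3)cc2F)c1/C=N/OCCO` gives 2.37 in this assay; against the other two it shows a number 1.04 log units lower from compound 2 to compound 3 (beyond the scatter) and a number 1.28 log units lower from compound 1 to compound 3 (beyond the scatter), both of them the only large moves in the set and both tied to a hydroxy entering the chain.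

Compound 4 `Nc1ncnc(Oc2ccc(NC(=O)C3(C(=O)Nc4ccc(F)cc4)CC3)cc2F)c1/C=N/OC1CCCC1` is the next member, not yet measured. Its difference from compound 2 is cyclopentyl in place of ethyl on an oxygen. Within the data shown here, of the measured steps, only the one from compound 1 to compound 2 changes the group on this same oxygen without adding a hydroxy, and that step stayed within the scatter. The two hydroxy steps run the other way and say nothing directly about a five-carbon ring replacing ethyl. Among the measured compounds shown here, no measured step adds three carbons and a ring, so the expectation rests on the size of the entering group alone.

For compound 4 a rise beyond the scatter is expected, a number 1.19 log units higher from compound 2 to compound 4 (beyond the scatter). Compound 4 is estimated at 4.6 in this assay, in the range 4.1 to 5.1.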

Compound 4, partition coefficient: 4.27
Compound 4: the middle estimate sits 0.33 log units above what was measured, within the range that was stated.
By their numbers in this assay, from the lowest: compound 3; then compounds 2 and 1 (each within the scatter of the next); then compound 4.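

In this assay, cyclopentyl on the oxygen gives a number 0.86 log units higher from compound 2 to compound 4 (beyond the scatter), so a group without a hydroxy can move the read-out beyond the scatter at this position, and here the move is upward. Allyl and ethyl could not be told apart, as compound 1 and compound 2 stay within the scatter of each other, but cyclopentyl stands clear of both, with a number 0.62 log units higher from compound 1 to compound 4 (beyond the scatter) adding to the step from ethyl; compound 4 is now the highest of the four, and the span at this one oxygen reaches a number 1.90 log units higher from compound 3 to compound 4 (beyond the scatter), wider than any earlier step. Nothing available on the series accounts for these differences.

From the compounds shown here alone, whether the rise goes with the ring or with the count of carbons stays open: a straight pentyl chain on this oxygen would separate the two, and cyclopropyl or cyclohexyl would show how the step changes with ring size. Also open, going by these compounds, is how an amine or a carboxylic acid at the end of the ethyl chain would compare with the hydroxy of compound 3 at 2.37.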